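Swapping the amide substituent on a shared bicyclic core

The compounds below may be only part of what the source reports. "The series", "measured", "known", "first", "only" and "open" are said of these compounds alone.

The compounds here share one core, seen in compound 1 `CC(C)=CCCC1=CC[C@@H](C(=O)Nc2ccc(C(=O)O)cc2)[C@H](c2ccccc2)C1`, which in an assay on isolated protein for inhibition of Apoptosis regulator Bcl-2 (Homo sapiens), read by fluorescence polarization, with stated times of 5 min and 10 min (a higher number here means a weaker inhibitor, a lower number a stronger inhibitor), gives 2200 nM. Compound 3 `CC(C)=CCCC1=CC[C@@H](C(=O)N(C)O)[C@H](c2ccccc2)C1` carries a hydroxy(methyl)amino group in place of the (4-carboxyphenyl)amino group of compound 1, and in this assay compound 3 gives 2300 nM. Among the two numbers known, compound 3 stands highest, yet the step of a 1.0-fold higher number from compound 1 to compound 3 (0.02 log units; within the scatter) sits within the scatter, so the two cannot be ranked. Compound 2 `COc1ccc(NC(=O)[C@H]2CC=C(CCC=C(C)C)C[C@@H]2c2ccccc2)cc1` in this assay reaches only a limit, > 23000 nM, at which one of the three values sits (the limit of > 23000 nM in this assay, at which 1 of the 3 values shown sits).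

Compound 4 `COc1ccc(NC(=O)[C@@H]2CC=C(CCC=C(C)C)C[C@H]2c2ccccc2)cc1` is the mirror image of compound 2 and differs from compound 3 as follows: (4-methoxyphenyl)amino in place of hydroxy(methyl)amino on a carbonyl carbon. For the measured compounds named here, the one measured step, that from compound 1 to compound 3, shows that replacing one amide substituent by another of quite different size left the number essentially unchanged. On that basis the expected step of a 1.7-fold higher number from compound 3 to compound 4 (0.24 log units; within the scatter) is small, with some risk that compound 4 drifts weaker toward the limit seen for its mirror image. Compound 4 is therefore estimated at 4000 nM, within a range from 1500 nM to 20000 nM.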

Compound 4, inhibition constant: > 23000 nM
Compound 4: only a limit was reported; the forecaster's own chance of this, stated with the estimate: 25%; middle value at least 5.7-fold (0.75 log units) away from the limit.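

In this assay compound 4 reaches only a limit, > 23000 nM, and not a true number. The step of an at least 10-fold higher number from compound 3 to compound 4 (1.00 log units; beyond the scatter) shows that this place, on a carbonyl carbon, does not accept every amide substituent alike, even though the earlier step of a 1.0-fold higher number from compound 1 to compound 3 (0.02 log units; within the scatter) lay within the scatter and suggested that it might. For the compounds shown here, the step of an at least 10-fold higher number from compound 1 to compound 4 (1.01 log units; beyond the scatter) adds something the earlier compounds could not show: with the rest of the molecule unchanged, methoxy in place of carboxy on an aromatic carbon is enough to separate the two compounds beyond the scatter.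

Going by these compounds, the step between the two mirror images cannot be read, so whether the configuration as drawn matters at all stays open, because both sit at the same limit and neither can be ranked against the other: the limit of > 23000 nM in this assay, at which 2 of the 4 values shown sit. Also open is how an amine or a hydroxyl group would read in place of methoxy on that aromatic carbon, and how far the carboxy group of compound 1 would carry over to the opposite configuration, given this pair: the fact that compounds 2 and 4 differ only in the configuration as drawn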